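This account rests on a few compounds, and the source may have more. Where it says the series, first, only, none or still open, it means among the compounds named here.

Measured compounds in a functional assay on MCF7 cells (Homo sapiens) for antiproliferative activity, read by MTT assay, with a stated time of 24 h; a lower number here means a stronger inhibitor, a higher number a weaker inhibitor:
- compound 1 `CCn1c(C(=O)NCCO)ccc1C(CC)(CC)c1ccc(OCS(=O)(=O)c2ccccc2)c(C)c1` gives 15500 nM
- compound 2 `CCn1c(C(=O)NC2(CO)CC2)ccc1C(CC)(CC)c1ccc(OCS(=O)(=O)c2ccccc2)c(C)c1` gives 28800 nM
- compound 3 `CCn1c(C(=O)N[C@H](CC(=O)O)C(=O)O)ccc1C(CC)(CC)c1ccc(OCS(=O)(=O)c2ccccc2)c(C)c1` gives a value that is only a limit of the assay, > 50000 nM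

Compound 1 holds the lowest of the two numbers shown; compound 2 sits nearest to it, and the step of a 1.9-fold higher number from compound 1 to compound 2 (0.27 log units; within the scatter) lies within the scatter. The step of an at least 3.2-fold higher number from compound 1 to compound 3 (0.50 log units; beyond the scatter) is the only one beyond the scatter, and it ends at a limit (the limit of > 50000 nM in this assay, at which 1 of the 3 values shown sits). Between compound 2 and compound 3 the step of an at least 1.7-fold higher number from compound 2 to compound 3 (0.23 log units; that floor lies within the scatter) has a floor that lies within the scatter.

Compound 4 `CCn1c(C(=O)N[C@@H](CCC(=O)O)C(=O)O)ccc1C(CC)(CC)c1ccc(OCS(=O)(=O)c2ccccc2)c(C)c1` has not been measured. Relative to compound 1 the change is 1,3-dicarboxypropyl in place of 2-hydroxyethyl on an amide-type nitrogen. The step that bears on it is an at least 3.2-fold higher number from compound 1 to compound 3 (0.50 log units; beyond the scatter), where a dicarboxyalkyl group also replaced the 2-hydroxyethyl on the amide-type nitrogen; the 1,3-dicarboxypropyl of compound 4 is the next longer member of that kind. A higher number is therefore expected in this assay, most likely again reaching the limit of the assay. For compound 4 the expected step from compound 1 is a 3.9-fold higher number from compound 1 to compound 4 (0.59 log units; beyond the scatter). Compound 4 is estimated at 60000 nM, with a range of 25000 nM to 150000 nM.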

Compound 4, half-maximal inhibitory concentration: > 50000 nM
Compound 4 ended at the assay's limit; the forecaster's own chance of this, stated with the estimate: 65%; the middle value does not contradict the limit.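

In this assay compound 4 gives > 50000 nM, which is a limit of the assay and not a number. Lengthening the dicarboxyalkyl group on the amide-type nitrogen does not bring the number back within reach of compound 1, and the replacement of 2-hydroxyethyl by 1,3-dicarboxypropyl gives an at least 3.2-fold higher number from compound 1 to compound 4 (0.50 log units; beyond the scatter), so two dicarboxyalkyl groups now give a step beyond the scatter. The step of an at least 1.7-fold higher number from compound 2 to compound 4 (0.23 log units; that floor lies within the scatter) adds only a floor, and the step between the two dicarboxyalkyl compounds cannot be read, since both sit at the limit: the limit of > 50000 nM in this assay, at which 2 of the 4 values shown sit.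

As far as these compounds go, whether a single carboxylic acid, a methyl ester of either dicarboxyalkyl group or an amine on the same chain would give a readable number remains open. From the compounds shown here alone, how far compound 3 and compound 4 lie past the limit also stays unknown.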